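This account rests on a few compounds, and the source may have more. Where it says the series, first, only, none or still open, it means among the compounds named here.

Measured compounds in a functional assay on the whole organism for agonist activity, with Mus musculus as the target; on this read-out higher numbers stand for an effect only at larger amounts of compound and lower numbers for an effect already at smaller amounts:
Compound 1 `CC(C#CCn1ccnc1)N1CCCC1=O` gives > 100 mg/kg, a limit of the assay and not a number.
Compound 2 `Cc1cncn1CC#CC(C)N1CCCC1=O` gives > 100 mg/kg, again a limit rather than a number.
Among the compounds with values here, compound 3 `COC(=O)N(C)CC#CCn1ccnc1` gives 2 mg/kg, the only number in the set.

Compound 1 and compound 2 differ by methyl in place of hydrogen on an aromatic carbon. The step between them in this assay, a step that the two limits leave unreadable from compound 1 to compound 2, cannot be read because of the limit of > 100 mg/kg in this assay, at which 2 of the 3 values shown sit. Compound 4 `COC(=O)N(C)CC#CCn1cncc1C`, not yet measured, carries the same change against compound 3, namely (methyl in place of hydrogen on an aromatic carbon). The difference between the core of compound 3 and the core of compound 1 is not broken down here. The earlier step gives no size to lean on. The step from compound 3 to compound 4 is therefore estimated at a 1.5-fold higher number from compound 3 to compound 4 (0.18 log units; within the scatter), expected to stay within the usual scatter. That rests on compound 3, whose 2 mg/kg is the only numbered anchor. Compound 4 is expected at 3 mg/kg, between 1 mg/kg and 15 mg/kg.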

Compound 4, dose for half-maximal effect: 4.5 mg/kg
Estimate against measurement, compound 4: 1.5-fold (0.18 log units) below, within the range that was stated.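

On the core of compound 3, methyl in place of hydrogen on an aromatic carbon gives a 2.3-fold higher number from compound 3 to compound 4 (0.35 log units; beyond the scatter) in this assay and so has a modest but readable effect on this core. This single pair shows the size of the change on one core only, and it does not show that the same size holds on any other core. The matching step from compound 1 to compound 2 cannot be read, because both values are limits of the assay: the limit of > 100 mg/kg in this assay, at which 2 of the 4 values shown sit.

Open, going by these compounds, is how a larger group in the same place, such as ethyl or trifluoromethyl, would read on the core of compound 3. Also open, on these data alone, is whether an amine or a carboxylic acid would be tolerated there.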